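The source may report more compounds than this note shows. Statements on the series, on what has been measured and on what is new or still open speak of the compounds shown alone.

Measured compounds:

Compound 1, `CC[C@@H]1C(=O)N(C)c2cnc(-n3ccc4cc(C(=O)NCC(C)C)ccc43)nc2N1C1CCCC1`, in a functional assay on HeLa cells (Homo sapiens) for antiproliferative activity, read by CCK-8 assay, with a stated time of 72 h (a higher number here means a weaker inhibitor of growth, a lower number a stronger inhibitor of growth), gives 3280 nM.
Compound 2, `CCC1C(=O)N(C)c2cnc(-n3ccc4cc(C(=O)NCC(C)C)ccc43)nc2N1c1ccn(C)n1`, in this assay gives 4970 nM.
Compound 3, `CC[C@@H]1C(=O)N(C)c2cnc(-n3ccc4cc(C(=O)NC5CCCC5)ccc43)nc2N1C1CCCC1`, in this assay gives 247 nM.

Compounds 1 and 3 share a core and differ in one place only: cyclopentyl in place of isobutyl on an amide-type nitrogen. That single change produced a large step in this assay, namely a 13-fold lower number from compound 1 to compound 3 (1.12 log units; beyond the scatter). Compound 2 carries a different core from compound 1; how the two cores differ is not broken down here. The values of compound 2 and compound 1 in this assay lie within the usual scatter of each other, so nothing separates them, while compound 3 stands well apart from both.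

Compound 4, `CCC1C(=O)N(C)c2cnc(-n3ccc4cc(C(=O)NC5CCCC5)ccc43)nc2N1c1ccn(C)n1`, has not yet been measured. It is built from compound 2 by the same change that leads from compound 1 to compound 3: cyclopentyl in place of isobutyl on an amide-type nitrogen. The place of the change is described in identical words for both pairs, so the change counts as the same one on a different core.

The expectation for compound 4 rests on the step seen in this assay with a 13-fold lower number from compound 1 to compound 3 (1.12 log units; beyond the scatter), and the step from compound 2 to compound 4 is therefore estimated at an 11-fold lower number from compound 2 to compound 4 (1.04 log units; beyond the scatter). Since that step has been observed only once and on a different core, the estimate is held loosely. Compound 4 is expected to give about 450 nM in this assay, with a likely range from 150 nM to 1500 nM.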

Compound 4, concentration for 50% growth inhibition: 27400 nM
Compound 4: the middle estimate sits 61-fold (1.78 log units) below what was measured, outside the stated range (above it).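

In this assay, cyclopentyl in place of isobutyl on an amide-type nitrogen did not behave alike on the two cores: on the core of compound 2 it gave a 5.5-fold higher number from compound 2 to compound 4 (0.74 log units; beyond the scatter), a step in the opposite direction to the one on the core of compound 1, as the two steps set side by side show: the same change on two cores in this assay, a 13-fold lower number (1.12 log units; beyond the scatter) from compound 1 to compound 3 and a 5.5-fold higher number (0.74 log units; beyond the scatter) from compound 2 to compound 4, 73-fold (1.86 log units) apart, beyond the scatter of two such steps The result therefore shows that, for these two pairs, the outcome of this change depends on the core that carries it, so a step read on one core cannot simply be transferred to the other. Going by these compounds alone, it does not show which difference between the two cores is responsible, nor does it explain the reversal, and with only one pair on each core it offers no general rule for the series.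

The compounds shown leave open whether a cyclohexyl group or a longer alkyl chain on the same amide-type nitrogen would follow the direction seen on the core of compound 1 or that seen on the core of compound 2. They also leave open whether the reversal is specific to the exchange of isobutyl and cyclopentyl or would appear with other pairs of groups at that place.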